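Swapping the aryl on the alkene of a sulfonyl enone

The source may report more compounds than this note shows. Statements on the series, on what has been measured and on what is new or still open speak of the compounds shown alone.

Compound 1 `COc1ccc(/C=C(\C(=O)c2ccc(Br)cc2)S(=O)(=O)c2ccc(Br)cc2)c(F)c1` gives 10000 nM in a functional assay on DU-145 cells (Homo sapiens) for inhibition, read by trypan blue exclusion, with a stated time of 96 h (a higher number here means a weaker inhibitor of growth, a lower number a stronger inhibitor of growth), the second highest of the three numbers measured. Compound 3 `COc1ccc(/C=C(/Sc2ccc(Br)cc2)C(=O)c2ccc(Br)cc2)c(F)c1` gives 20000 nM, and the step of a 2.0-fold higher number from compound 1 to compound 3 (0.30 log units; within the scatter) stays within the scatter. Compound 2 `O=C(/C(=C\c1ccc(F)cc1C(F)(F)F)S(=O)(=O)Cc1ccc(Cl)c(Cl)c1)c1ccc(Cl)cc1` gives 1000 nM, a lower number, but it differs from compound 1 in several places at once, so the two values alone cannot be assigned to any one change. Compound 4 `O=C(/C(=C\c1ccc(F)cc1Cl)S(=O)(=O)c1ccc(Br)cc1)c1ccc(Br)cc1` carries 2-chloro-4-fluorophenyl in place of 2-fluoro-4-methoxyphenyl on a double-bonded chain carbon bound to a double-bonded chain carbon. Among the compounds with values here, no measured step alters this group alone; the one measured step touches the sulfur group instead. Compound 4 is therefore expected to shift only modestly, a 2.0-fold lower number from compound 1 to compound 4 (0.30 log units; within the scatter), toward a lower number. The estimate for compound 4 is 5000 nM, within a range from 1500 nM to 15000 nM.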

Compound 4, concentration for 50% growth inhibition: 50000 nM
Compound 4: middle estimate off by 10-fold (1.00 log units), on the low side; measured number outside the range, above it.
By their numbers in this assay, from the lowest: compound 2; then compounds 1 and 3 (each within the scatter of the next); then compound 4.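

In this assay, within the data shown here, the step at this position is a 5.0-fold higher number from compound 1 to compound 4 (0.70 log units; beyond the scatter), so the group on the double-bonded chain carbon matters more here than the one sulfur change measured earlier. Placing 2-chloro-4-fluorophenyl in place of 2-fluoro-4-methoxyphenyl weakens growth inhibition on this sulfonyl scaffold. Nothing available explains this shift.

The compounds shown leave open whether losing the methoxy or gaining the chlorine carries the step. They also leave open how an amine or a carboxylic acid on this phenyl would read.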